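This account rests on a few compounds, and the source may have more. Where it says the series, first, only, none or still open, it means among the compounds named here.

Working notes on the series. In a physicochemical assay for solubility, at pH 7 (a higher number here means a more soluble compound, a lower number a less soluble compound), compound 1 (`CN1CCC(C(=O)N2Cc3c(NC(=O)c4ccc(Cl)cc4)n[nH]c3C2(C)C)CC1`) gives > 225000 nM as a limit of the assay, not a number. Compound 2 (`CC(C)CC(=O)Nc1n[nH]c2c1CN(C(=O)C1CCN(C3CC3)CC1)C2(C)C`) gives > 225000 nM as a limit too. For the measured compounds named here, compound 3 (`CC(C)(C)C(=O)N1Cc2c(NC(=O)c3ccncc3)n[nH]c2C1(C)C`) gives 205000 nM as the only true number so far. Compound 4 (`CCCNC(=O)Nc1n[nH]c2c1CN(C(=O)C1CCN(C)CC1)C2(C)C`) carries propylamino in place of 4-chlorophenyl on a carbonyl carbon. Going by the values given here, no measured pair shows this change. Compound 1 sits at the limit of > 225000 nM in this assay, at which 2 of the 3 values shown sit, and that is the sole ground for the expectation. The expected step, a number no higher from compound 1 to compound 4 (the limit leaves the size open), is estimated to stay within the scatter, in neither direction. For compound 4 the estimate is 225000 nM with an expected range from 150000 nM to 300000 nM in this read-out.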

Compound 4, solubility: > 225000 nM
Compound 4: no number, only a limit; the forecaster's own chance of this, stated with the estimate: 75%; the middle value sits exactly at the limit.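

No step can be read between compound 1 and compound 4: both values in this assay are limits of the assay, not numbers. The compounds shown leave open whether propylamino in place of 4-chlorophenyl on a carbonyl carbon shifts this read-out at all.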